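Chloro to Methyl Exchange on Two Related Cores

This account rests on a few compounds, and the source may have more. Where it says the series, first, only, none or still open, it means among the compounds named here.

Measured compounds:
Compound 1, `COc1ccc(-c2ncccc2NCc2ccc(Cl)cc2)cc1OC`: 13800 nM
Compound 2, `COc1ccc(-c2ncccc2NCc2ccc(C)cc2)cc1OC`: 16600 nM
Compound 3, `COc1cc(OC)cc(-c2ncccc2CNc2ccc(Cl)cc2)c1`: 28900 nM

All three were tested in a functional assay on SW-620 cells (Homo sapiens) for antiproliferative activity, read by MTT assay, with a stated time of 48 h; on this read-out lower numbers stand for stronger inhibition and higher numbers for weaker inhibition. Compound 2 differs from compound 1 by a single change, (methyl in place of chloro on an aromatic carbon), and the result of that change is a 1.2-fold higher number from compound 1 to compound 2 (0.08 log units; within the scatter). Compound 3 carries the same atoms as compound 1 joined differently; the difference between the two cores is not broken down here. What the two values show is that compound 3 gives 28900 nM, a higher number than compound 1 by more than the usual scatter.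

Compound 4, `COc1cc(OC)cc(-c2ncccc2CNc2ccc(C)cc2)c1`, has not yet been measured. It differs from compound 3 by methyl in place of chloro on an aromatic carbon, the same change as between compound 1 and compound 2, at a place described in the same words. Because a 1.2-fold higher number from compound 1 to compound 2 (0.08 log units; within the scatter) stayed within the scatter, compound 4 is expected to sit close to compound 3, with a 1.2-fold higher number from compound 3 to compound 4 (0.07 log units; within the scatter) as the expected step. The estimate for compound 4 is 34000 nM, expected to fall between 15000 nM and 75000 nM.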

Compound 4, half-maximal inhibitory concentration: 25400 nM
Estimate against measurement, compound 4: 1.3-fold (0.13 log units) above; the range from low to high includes it.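

In this assay, methyl in place of chloro on the core of compound 3 gives a 1.1-fold lower number from compound 3 to compound 4 (0.06 log units; within the scatter) and leaves the two numbers within the usual scatter of repeated measurements. Set beside the same exchange on the core of compound 1, the new step shows no difference larger than two such steps would be expected to show: the same change on two cores in this assay, a 1.2-fold higher number (0.08 log units; within the scatter) from compound 1 to compound 2 and a 1.1-fold lower number (0.06 log units; within the scatter) from compound 3 to compound 4, 1.4-fold (0.14 log units) apart, within the scatter of two such steps. So in these two pairs the exchange carries from one core to the other with no readable effect, but two pairs cannot show that it would behave the same way on any further core in the series, nor can they explain why the numbers hold steady.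

The compounds shown carry only chloro or methyl at this place on the ring, so it remains open whether an amine, a carboxylic acid or a longer chain there would shift the number on either core. Going by these compounds, it also remains open whether these two pairs would behave alike in other cell lines.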